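This account rests on a few compounds, and the source may have more. Where it says the series, first, only, none or still open, it means among the compounds named here.

Compound 1 `COc1ccc(C(=O)NCCCOc2cc(=O)n(CCCO)c3c2CC(CC=C(C)C)C(C)(C)C3)cc1` and compound 2 `CC(C)=CCC1Cc2c(OCCCNC(=O)c3cccs3)cc(=O)n(CCCO)c2CC1(C)C` share one core and differ only in the group on a carbonyl carbon. In a functional assay on PANC-1 cells (Homo sapiens) for inhibition, read by MTT assay, with a stated time of 24 h, tested at 10 uM (a lower number here means less inhibition, a higher number more inhibition at the concentration tested (going by the name of the read-out)), compound 1 gives 2.5%, and compound 2 gives 5.6%. Among the measured compounds shown here, the single measured step, a number 3.1 percentage points higher from compound 1 to compound 2 (within the scatter), lies within the usual scatter, so compound 2 stands alongside compound 1 rather than apart from it. Compound 3 `CC(C)=CCC1Cc2c(OC(=O)Nc3ccccc3F)cc(=O)n(CCCO)c2CC1(C)C` brings a broader change: (2-fluorophenyl)carbamoyl in place of 3-(((thiophen-2-yl)carbonyl)amino)propyl on an oxygen on an aromatic ring. For the measured compounds named here, no measured step covers a change of this kind, because the only known step, a number 3.1 percentage points higher from compound 1 to compound 2 (within the scatter), altered the group on a carbonyl carbon while the 3-(((thiophen-2-yl)carbonyl)amino)propyl chain itself stayed in place. Both measured numbers are low, and nothing seen so far points to a rise, so only a small step is expected, a number 1.4 percentage points higher from compound 2 to compound 3 (within the scatter). Compound 3 is therefore estimated at 7%, with a likely range from 0% to 22%.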

Compound 3, a percentage reported as inhibition, at one concentration (the size of the read-out at that concentration, not a potency): 0%
Compound 3: middle estimate off by 7 percentage points, on the high side, and the stated range covers the measured number.
By their numbers in this assay, from the lowest: compounds 3, 1 and 2 (each within the scatter of the next).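

In this assay, exchanging the whole 3-(((thiophen-2-yl)carbonyl)amino)propyl chain on the oxygen on an aromatic ring for (2-fluorophenyl)carbamoyl gives a number 5.6 percentage points lower from compound 2 to compound 3 (within the scatter) and so, like the earlier change on a carbonyl carbon, does not move the number beyond the usual scatter. At this position, then, two quite different groups cannot be told apart at the single concentration tested. No evidence is available that would explain this result.

On these data alone, whether another group on this oxygen, such as one carrying an amine, a carboxylic acid or a longer chain, would give a number clear of the scatter remains open. As far as these compounds go, all three compounds also keep the shared core, so the effect of changing it remains open too.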